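The source may report more compounds than this note shows. Statements on the series, on what has been measured and on what is new or still open speak of the compounds shown alone.

Measured so far in an assay on COS-7 cells for inhibition of patatin-like phospholipase domain-containing protein 2 (Mus musculus); a lower number here means a stronger inhibitor, a higher number a weaker inhibitor:
compound 1, `CCOC(=O)c1ccc(-c2ccc(OCC)cc2)[nH]1`, gives only a limit, > 200000 nM.
compound 2, `CCOC(=O)c1cccc(-c2ccc([N+](=O)[O-])cc2)c1`, gives 95000 nM.
compound 3, `CCOC(=O)c1cccc(-c2ccc(CN3CCN(C)CC3)o2)c1`, gives 120000 nM.

Compound 2 holds the lowest of the two numbers in this assay; compound 3 sits within the scatter of it, so no order between the two can be read. For compound 1 the value is a limit, not a number; (the limit of > 200000 nM in this assay, at which 1 of the 3 values shown sits).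

Compound 4, `CCOC(=O)c1cccc(-c2ccc(C(C)N(C)C)cc2)c1`, has not been measured. It differs from compound 2 in one place: 1-(dimethylamino)ethyl in place of nitro on an aromatic carbon. For the measured compounds named here, no measured pair shows this change, so the direction of any step is unknown; the expectation is for no step beyond the scatter in this assay. The estimate for compound 4 is 80000 nM, with a range of 20000 nM to 300000 nM. That estimate amounts to a step of a 1.2-fold lower number from compound 2 to compound 4 (0.07 log units; within the scatter).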

Compound 4, half-maximal inhibitory concentration: 200000 nM
Compound 4: middle estimate off by 2.5-fold (0.40 log units), on the low side; the range from low to high includes it.
By their numbers in this assay, from the lowest: compounds 2, 3 and 4 (each within the scatter of the next, the first and the last beyond it).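

In this assay, swapping nitro for 1-(dimethylamino)ethyl on the aromatic carbon gives a 2.1-fold higher number from compound 2 to compound 4 (0.32 log units; beyond the scatter). For the compounds shown here, this is the first sign that the position responds to its substituent, though the step is modest and rests on this single pair. The numbers also run close to the top of the assay, where compound 1 gives only a limit: the limit of > 200000 nM in this assay, at which 1 of the 4 values shown sits.

As far as these compounds go, it remains open whether the step follows from losing nitro or from the entering group. A carboxylic acid, a primary amine or a plain methyl at this position would help separate the two.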